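Fluoro to chloro on the outer aromatic ring

This account rests on a few compounds, and the source may have more. Where it says the series, first, only, none or still open, it means among the compounds named here.

Of the compounds shown here, three sharing one core have been tested in a functional assay on RD cells (Homo sapiens) for inhibition, read by luminescence and ATP content, with a stated time of 72 h; on this read-out lower numbers stand for higher toxicity in this test and higher numbers for lower toxicity in this test. Compound 1 `CCCCc1ccc(-c2ccc3ncc(-c4noc(C(F)(F)F)n4)cc3c2)cc1` carries a butyl group on an aromatic carbon; in this assay compound 1 gives only a limit, > 7400 nM. Compound 2 `FC(F)(F)c1nc(-c2cnc3ccc(-c4ccccc4)cc3c2)no1` has hydrogen in that place, and in this assay compound 2 reaches only a limit, > 22200 nM. Compound 3 `Fc1ccc(-c2ccc3ncc(-c4noc(C(F)(F)F)n4)cc3c2)cc1` carries fluoro there; in this assay compound 3 gives only a limit, > 7400 nM. The steps a step that the two limits leave unreadable from compound 1 to compound 2, a step that the two limits leave unreadable from compound 1 to compound 3 and a step that the two limits leave unreadable from compound 2 to compound 3 cannot be sized, since each end is a limit: the limit of > 7400 nM in this assay, at which 2 of the 3 values shown sit, and (the limit of > 22200 nM in this assay, at which 1 of the 3 values shown sits). Compound 3 therefore stands at one of these limits, alongside compound 1.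

Compound 4 `FC(F)(F)c1nc(-c2cnc3ccc(-c4ccc(Cl)cc4)cc3c2)no1` differs from compound 3 by chloro in place of fluoro on an aromatic carbon. For the measured compounds named here, none of the measured steps can be read, so no direction or size beyond what the limits allow is expected, and the step that the limit leaves unreadable from compound 3 to compound 4 is an estimate only. Compound 4 is expected at 10000 nM, within a range from 4000 nM to 30000 nM, most probably reported once more as a limit.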

Compound 4, half-maximal cytotoxic concentration: > 200000 nM
Compound 4 ended at the assay's limit; the forecaster's own chance of this, stated with the estimate: 80%; middle value at least 20-fold (1.30 log units) from the limit.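

For the compounds shown here, all four values are limits, so no step from compound 1, compound 2 or compound 3 to compound 4 can be read. The compounds shown leave open whether any of them has a measurable cytotoxic concentration in this assay, and whether chloro and fluoro differ there at all.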